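The source may report more compounds than this note shows. Statements on the series, on what has been measured and on what is new or still open speak of the compounds shown alone.

Measured compounds:
- compound 1, `CCOC(=O)C1=C(C)NC(C)=C(C(=O)OCC)C1c1ccc(OCC(=O)NNC(=O)c2ccccc2)cc1`: 29.5%
- compound 2, `CCOC(=O)C1=C(C)NC(C)=C(C(=O)OCC)C1c1ccc(OCC(=O)NNC(=O)c2ccsc2Cl)cc1`: 42.3%

In a functional assay on the whole organism (strain Wistar) for inhibition, with Rattus norvegicus as the target, read by paw edema, with stated times of 30 min and 1 h, at a dose of 20 mg/kg (on this read-out higher numbers stand for more inhibition at the one dose given (going by the name of the read-out) and lower numbers for less inhibition), compound 1 gives 29.5%, and compound 2 gives 42.3%. Among the measured compounds shown here, compound 2 thus stands highest of the two numbers, the only other compound being compound 1, and the step of a number 12.8 percentage points higher from compound 1 to compound 2 (beyond the scatter) lies beyond the scatter. For the measured compounds named here, that single step, 2-chlorothiophen-3-yl in place of phenyl on a carbonyl carbon, is the only measured change, and it alters an aryl group at the end of the side chain while keeping the rest of the side chain intact.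

Compound 3, `CCOC(=O)C1=C(C)NC(C)=C(C(=O)OCC)C1c1ccc(OCC(=O)n2nc(C)cc2C)cc1`, differs from compound 2 at the same carbonyl carbon: a group of 7 heavy atoms (5 carbon, 2 nitrogen; one five-membered aromatic ring with 2 hetero atoms) in place of a group of 10 heavy atoms (5 carbon, 2 nitrogen, 1 oxygen, 1 sulfur, 1 chlorine; one five-membered aromatic ring with 1 hetero atom), on a carbonyl carbon. Going by the values given here, no measured step covers a change of this kind, since the step from compound 1 to compound 2 swaps one aryl ring for another without touching the rest of the chain. The step from compound 2 to compound 3 is therefore expected to be of a different character, and no direction can be read from the data. The step is expected to be a number 6.3 percentage points lower from compound 2 to compound 3 (within the scatter), within the scatter. Compound 3 is expected to give about 36% in this assay, with a range from 20% to 52%.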

Compound 3, a percentage reported as inhibition, in the whole organism at one dose (the size of the read-out at that dose, not a potency): 32.7%
Estimate against measurement, compound 3: 3.3 percentage points above; measured number inside the range.
By their numbers in this assay, from the lowest: compounds 1, 3 and 2 (each within the scatter of the next, the first and the last beyond it).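

The result shows that this carbonyl carbon accepts a far larger change than the swap of one aryl ring for another. With 3,5-dimethyl-1H-pyrazol-1-yl in place of benzamidoamino, this assay gives a number 3.2 percentage points higher from compound 1 to compound 3 (within the scatter), while the comparison with the 2-chlorothiophene compound gives a number 9.6 percentage points lower from compound 2 to compound 3 (within the scatter), so compound 3 cannot be separated from either, even though those two compounds stand apart from each other. No measurement offered here explains these numbers or links them to any property of the groups.

The compounds shown leave open whether a simple amine such as morpholine, or a hydroxyl group that would make this carbonyl a carboxylic acid, would read differently from compound 3 on the same carbonyl carbon. They also leave open whether a pyrazole without the two methyl groups would stay within the scatter of compound 3, and whether the same ordering would hold at any other dose or time.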